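The source may hold more compounds than are shown below. What is called first, only, known or untested is meant among the compounds shown, and "the series" means these compounds.

Measured in a functional assay on HCT-116 cells (Homo sapiens) for antiproliferative activity, read by sulforhodamine B assay, with a stated time of 72 h; a lower number here means a stronger inhibitor, a higher number a weaker inhibitor:
- Compound 1 `Cn1ncc(Cl)c1-c1cc(C(=O)N[C@@H]2CN[C@H](CC(=O)O)C[C@H]2c2ccc(Cl)c(Cl)c2)oc1Cl`: 4020 nM
- Compound 2 `Cn1ncc(Cl)c1-c1cc(C(=O)N[C@@H]2CN[C@H](CCN3CCCC3)C[C@H]2c2ccc(Cl)c(Cl)c2)oc1Cl`: 1940 nM

Compound 2 has the lower of the two numbers. Compound 3 `Cn1ncc(Cl)c1-c1cc(C(=O)N[C@@H]2CN[C@H](CC(=O)NC3CCC3)C[C@H]2c2ccc(Cl)c(Cl)c2)oc1Cl` differs from it by cyclobutylcarbamoyl in place of (pyrrolidin-1-yl)methyl on a saturated chain carbon bound to a saturated ring carbon, with cyclobutylcarbamoyl in place of (pyrrolidin-1-yl)methyl. Among the measured compounds shown here, the only measured step that bears on this change is modest: a 2.1-fold lower number from compound 1 to compound 2 (0.32 log units; beyond the scatter). It concerns the same place, and compound 3 again has a carbonyl there, as compound 1 does. A shift toward a higher number is therefore expected, but none beyond the scatter: the expected change is a 1.4-fold higher number from compound 2 to compound 3 (0.16 log units; within the scatter). For compound 3 the estimated value is 2800 nM, with an expected range of 900 nM to 7000 nM.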

Compound 3, half-maximal inhibitory concentration: 430 nM
The estimate for compound 3 lay 6.5-fold (0.81 log units) above the measured number; measured number below the stated range.
By their numbers in this assay, from the lowest: compound 3; then compound 2; then compound 1.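

In this assay, the group on a saturated chain carbon bound to a saturated ring carbon moves the number further than the earlier step showed: cyclobutylcarbamoyl in place of (pyrrolidin-1-yl)methyl gives a 4.5-fold lower number from compound 2 to compound 3 (0.65 log units; beyond the scatter). Cyclobutylamino in place of hydroxy on a carbonyl carbon gives a 9.3-fold lower number from compound 1 to compound 3 (0.97 log units; beyond the scatter), so the carbonyl shared by compound 1 and compound 3 does not alone set the number; what it carries matters. Nothing available explains these differences. A cyclopentyl amide or a dimethyl amide would show whether the ring size or the amide hydrogen goes with the lower number.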